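The source may hold more compounds than are shown below. What is called first, only, known or untested is meant among the compounds shown, and "the series" means these compounds.

Of the compounds shown here, three built on one shared core have been tested in a functional assay on HepG2 cells (Homo sapiens) for antiproliferative activity, read by MTT assay, with a stated time of 24 h; on this read-out lower numbers stand for stronger inhibition and higher numbers for weaker inhibition. Compound 1 `O=c1[nH]cc(S(=O)(=O)Nc2ccccc2-c2cn(-c3ccccc3F)nn2)c(=O)[nH]1` gives 12500 nM. Compound 2 `O=c1[nH]cc(S(=O)(=O)Nc2cccc(-c3cn(-c4ccccc4Cl)nn3)c2)c(=O)[nH]1` gives 4030 nM. Compound 3 `Cc1ccccc1-n1cc(-c2ccc(NS(=O)(=O)c3c[nH]c(=O)[nH]c3=O)cc2)nn1` gives 14500 nM, the highest of the three numbers. Compound 1 sits so close to compound 3 that the two fall within the usual scatter, and no order between them can be read. Compound 2 lies clearly lower than compound 3, a gap beyond the scatter.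

Compound 4 `O=c1[nH]cc(S(=O)(=O)Nc2ccc(-c3cn(-c4ccc(Cl)cc4)nn3)cc2)c(=O)[nH]1` differs from compound 3 in one place: 4-chlorophenyl in place of 2-methylphenyl on an aromatic nitrogen. Among the measured compounds shown here, no pair among the measured compounds isolates this exchange, so its effect has not been seen directly. Compound 2 also carries a chlorine on its outer ring and gives 4030 nM, but it differs from compound 4 in more than this one place, so it cannot settle the question. In this assay the expected step is a 1.6-fold lower number from compound 3 to compound 4 (0.21 log units; within the scatter), a small move toward a lower number that need not rise beyond the scatter. Compound 4 is estimated at 9000 nM, with a likely range from 3000 nM to 27000 nM.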

Compound 4, half-maximal inhibitory concentration: 1980 nM
The estimate for compound 4 lay 4.5-fold (0.66 log units) above the measured number; the whole stated range lies above it.
By their numbers in this assay, from the lowest: compound 4; then compound 2; then compounds 1 and 3 (each within the scatter of the next).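

Among the compounds shown here, with compound 3 and compound 4, the outer ring on the aromatic nitrogen is the only thing that differs, so this position can be read directly for the first time. In this assay, replacing 2-methylphenyl with 4-chlorophenyl, a group with the same count of heavy atoms, gives a 7.3-fold lower number from compound 3 to compound 4 (0.86 log units; beyond the scatter) and that step lies beyond the scatter, showing that the number responds to what sits at this position. Nothing measured here explains the size of this step.

The kind of group and its place on the outer ring change together in this exchange, so the step cannot be divided between the two. As far as these compounds go, how 4-methylphenyl, or an outer ring carrying an amine or a carboxylic acid, would behave at this position remains open.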